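Methyl to ethyl on compound 1: working notes

The source may hold more compounds than are shown below. What is called first, only, known or untested is meant among the compounds shown, and "the series" means these compounds.

- compound 1 `Cc1cc2ccccc2nc1-c1cn(CCC(F)(F)C(F)(F)C(F)(F)C(F)(F)C(F)(F)C(F)(F)C(F)(F)C(F)(F)F)nn1`: 75.8 ug/mL
- compound 2 `CCCCCCCCCCn1cc(-c2nc3ccccc3cc2CC)nn1`: > 100 ug/mL (a limit of the assay)

Among the compounds with values here, in a functional assay on COLO 205 cells (Homo sapiens) for cytotoxicity, read by MTT assay, with a stated time of 24 h (on this read-out lower numbers stand for stronger inhibition and higher numbers for weaker inhibition), compound 1 gives 75.8 ug/mL, the only actual number so far. Compound 2 reads > 100 ug/mL, which is a limit of the assay. The room left for measurement is narrow, given (the limit of > 100 ug/mL in this assay, at which 1 of the 2 values shown sits).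

The next compound is compound 3 `CCc1cc2ccccc2nc1-c1cn(CCC(F)(F)C(F)(F)C(F)(F)C(F)(F)C(F)(F)C(F)(F)C(F)(F)C(F)(F)F)nn1`, which departs from compound 1 by one small change: methyl in place of hydrogen on a saturated chain carbon bound to an aromatic carbon. This places methyl in place of hydrogen on a saturated chain carbon bound to an aromatic carbon, so that 3-methylquinolin-2-yl becomes 3-ethylquinolin-2-yl.

Within the data shown here, no measured pair calibrates this change. Among the measured compounds shown here, the only hint is compound 2, which carries the same 3-ethylquinolin-2-yl group and stays at the limit > 100 ug/mL, though its chain differs as well. In this assay a step within the usual scatter is expected, leaning if anything towards weaker inhibition. The expected change, a 1.1-fold higher number from compound 1 to compound 3 (0.05 log units; within the scatter), is an estimate only. For compound 3 the estimated value is 85 ug/mL, with an expected range of 50 ug/mL to 120 ug/mL.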

Compound 3, half-maximal inhibitory concentration: 95.2 ug/mL
Compound 3: the middle estimate sits 1.1-fold (0.05 log units) below what was measured, within the range that was stated.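

In this assay, the change from 3-methylquinolin-2-yl to 3-ethylquinolin-2-yl now has a measured pair with the rest of compound 1 unchanged, and it reads a 1.3-fold higher number from compound 1 to compound 3 (0.10 log units; within the scatter). Methyl in place of hydrogen on a saturated chain carbon bound to an aromatic carbon therefore leaves the two compounds indistinguishable on this read-out, which compound 2 alone could not show. Compound 2, which carries the same 3-ethylquinolin-2-yl group on a different chain, gives > 100 ug/mL, and this is a limit of the assay, not a number.

Going by these compounds, whether this position responds at all remains open, since the values shown have little room to separate: the limit of > 100 ug/mL in this assay, at which 1 of the 3 values shown sits A longer chain such as propyl or butyl in place of the ethyl, or an amine or a carboxylic acid on that chain, would test whether any change here moves the read-out beyond the usual scatter.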